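Catechol hydroxylation repeated on a second core

The source may hold more compounds than are shown below. What is called first, only, known or untested is meant among the compounds shown, and "the series" means these compounds.

Compound 2 `O=C(C1=C(O)/C(=C/c2ccc(O)cc2)CCC1)c1ccccc1` and compound 1 `O=C(C1=C(O)/C(=C/c2ccc(O)c(O)c2)CCC1)c1ccccc1` share one core; compound 3 `O=C(/C=C(O)/C=C/c1ccc(O)cc1)c1ccccc1O` and compound 4 `O=C(/C=C(O)/C=C/c1ccc(O)c(O)c1)c1ccccc1O` share another, and the difference between the two cores is not broken down here. In an assay on isolated protein for inhibition of Alpha glucosidase (Homo sapiens), with stated times of 5 min and 15 min, tested at 50 uM (on this read-out lower numbers stand for less inhibition and higher numbers for more inhibition at the one concentration tested (going by the name of the read-out)), compound 1 gives 55.9%. Compound 2 gives 34.9% in this assay. Compound 3 gives 20.4% in this assay, the lowest of the three numbers. The change hydroxy in place of hydrogen on an aromatic carbon made a step of a number 21 percentage points higher from compound 2 to compound 1 (beyond the scatter). The same change, occurring twice among these compounds, carries compound 3 to compound 4: hydroxy in place of hydrogen on an aromatic carbon. Going by the values given here, for compound 4 the expected step is a number 19.6 percentage points higher from compound 3 to compound 4 (beyond the scatter), resting on the single precedent a number 21 percentage points higher from compound 2 to compound 1 (beyond the scatter) on the other core, with wider uncertainty since only one precedent exists. Compound 4 is estimated at 40%, with a likely range from 24% to 56%.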

Compound 4, a percentage reported as inhibition, at one concentration (the size of the read-out at that concentration, not a potency): 93.6%
The estimate for compound 4 lay 53.6 percentage points below the measured number; measured number above the stated range.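

In this assay the hydroxy in place of hydrogen on an aromatic carbon makes a step of a number 73.2 percentage points higher from compound 3 to compound 4 (beyond the scatter) and so points the same way as on the other core, but the size of the step does not carry over: the same change on two cores in this assay, a number 21 percentage points higher (beyond the scatter) from compound 2 to compound 1 and a number 73.2 percentage points higher (beyond the scatter) from compound 3 to compound 4, 52.2 percentage points apart, beyond the scatter of two such steps.
Direction held on both cores, so a step measured on one core gave the sign of the step on the other but not its size. Two pairs do not show which feature of the cores sets the gap, or whether the direction would hold on a third core.

Still open, from the compounds shown here alone, is whether a methoxy group, an amine or a fluorine on the aromatic carbon ortho to the hydroxy group would move the number the same way. These percentages, each read at one concentration, also say nothing about potency.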